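The source may report more compounds than this note shows. Statements on the series, on what has been measured and on what is new or still open speak of the compounds shown alone.

Working notes on the series, read in a functional assay on HT-29 cells (Homo sapiens) for inhibition, with a stated time of 72 h; on this read-out higher numbers stand for weaker inhibition and lower numbers for stronger inhibition. Compound 1 `COc1ccc(S(=O)(=O)N2CCc3cccc(-c4ccc(N)cc4)c32)cc1` gives 301 nM, compound 2 `COc1ccc(S(=O)(=O)N2CCc3cccc(-c4ccc(F)nc4)c32)cc1` gives 109 nM and compound 3 `COc1ccc(-c2cccc3c2N(S(=O)(=O)c2ccc(OC)cc2)CC3)cc1` gives 277 nM. Compound 3 therefore sits with compound 1, the two lying within the scatter of each other, and both carry higher numbers than compound 2.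

The change under review leads to compound 4 `COc1ccc(S(=O)(=O)N2CCc3cccc(-c4cccnc4)c32)cc1`: pyridin-3-yl in place of 4-methoxyphenyl on an aromatic carbon.

The closest measured step is a 2.5-fold higher number from compound 2 to compound 3 (0.41 log units; beyond the scatter), which is modest and also exchanges a pyridine-type group for 4-methoxyphenyl on that carbon. The step of a 2.8-fold lower number from compound 1 to compound 2 (0.44 log units; beyond the scatter) is similar in size, whereas a 1.1-fold lower number from compound 1 to compound 3 (0.04 log units; within the scatter) stays within the scatter. Among these three compounds, the only one with a pyridine-type group has the lowest number. However, compound 4 lacks the fluorine of compound 2, and no measured step isolates that fluorine, so only part of the gap may carry over.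

A small move toward a lower number is therefore expected, and it may not clear the scatter. The expected change is a 1.7-fold lower number from compound 3 to compound 4 (0.24 log units; within the scatter). Compound 4 is estimated at 160 nM, with an expected range from 65 nM to 390 nM.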

Compound 4, half-maximal inhibitory concentration: 76.3 nM
Estimate against measurement, compound 4: 2.1-fold (0.32 log units) above; measured number inside the range.
By their numbers in this assay, from the lowest: compounds 4 and 2 (each within the scatter of the next); then compounds 3 and 1 (each within the scatter of the next).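

In this assay, the unsubstituted pyridin-3-yl ring at this aromatic carbon is enough to set the series apart from the two phenyl compounds, both against 4-methoxyphenyl (a 3.6-fold lower number from compound 3 to compound 4 (0.56 log units; beyond the scatter)) and against 4-aminophenyl (a 3.9-fold lower number from compound 1 to compound 4 (0.60 log units; beyond the scatter)). Compound 2 and compound 4 cannot be separated (a 1.4-fold lower number from compound 2 to compound 4 (0.15 log units; within the scatter)), so the fluoro group of 6-fluoropyridin-3-yl is not required for the lower numbers that these two pyridine compounds show against compound 1 and compound 3, and within these four compounds none goes against that split. No supporting data accompany these values to account for the gap between the pyridine and phenyl compounds.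

The compounds shown leave open whether the ring nitrogen must sit where it does in pyridin-3-yl, a question that pyridin-4-yl or pyridin-2-yl at the same carbon would address. They also leave open how far this carbon tolerates other groups on the pyridine ring, such as a methoxy or an amine in place of the fluoro of compound 2, or a different ring such as pyrimidin-5-yl.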